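The source may report more compounds than this note shows. Statements on the series, on what has been measured and on what is new or still open speak of the compounds shown alone.

Of the compounds shown here, three have been measured in a functional assay on HeLa cells (Homo sapiens) for inhibition, read by MTT assay, with a stated time of 48 h; a lower number here means a stronger inhibitor, a higher number a weaker inhibitor. Compound 1 (`O=C(/C=C/c1cccc([N+](=O)[O-])c1)c1ccc[nH]1`) gives 32000 nM. Compound 2 (`O=C(/C=C/c1ccc(Cl)cc1)c1ccc[nH]1`) gives 25000 nM, and compound 3 (`O=C(/C=C/c1ccc(Cl)cc1)c1ccco1`) gives 38000 nM. Compounds 2 and 3 differ in one place, (furan-2-yl in place of 1H-pyrrol-2-yl on a carbonyl carbon), and this change gave a 1.5-fold higher number from compound 2 to compound 3 (0.18 log units; within the scatter). The difference between the core of compound 1 and the core of compound 2 is not broken down here.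

Compound 4 (`O=C(/C=C/c1cccc([N+](=O)[O-])c1)c1ccco1`) has not yet been measured in this assay. It carries the same change relative to compound 1, (furan-2-yl in place of 1H-pyrrol-2-yl on a carbonyl carbon), at the same place. Among the measured compounds shown here, for compound 4 a step of a 1.4-fold higher number from compound 1 to compound 4 (0.15 log units; within the scatter) is expected, because the one earlier instance of this change gave a 1.5-fold higher number from compound 2 to compound 3 (0.18 log units; within the scatter). Compound 4 is therefore estimated at 45000 nM in this assay, with the expected range running from 22000 nM to 90000 nM.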

Compound 4, half-maximal inhibitory concentration: 22000 nM
The estimate for compound 4 lay 2.0-fold (0.31 log units) above the measured number; the range from low to high includes it.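

In this assay, furan-2-yl in place of 1H-pyrrol-2-yl on the carbonyl carbon gave a 1.5-fold lower number from compound 1 to compound 4 (0.16 log units; within the scatter). Set beside the earlier instance of this change, neither step nor the gap between them lies beyond the scatter: the same change on two cores in this assay, a 1.5-fold higher number (0.18 log units; within the scatter) from compound 2 to compound 3 and a 1.5-fold lower number (0.16 log units; within the scatter) from compound 1 to compound 4, 2.2-fold (0.34 log units) apart, within the scatter of two such steps. The change can thus be carried between these two cores without any step standing out from the scatter, but these two pairs do not establish a consistent effect of the change, nor do they show how it would behave on other cores.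

The compounds shown leave open how a thiophen-2-yl or phenyl group on the carbonyl carbon would read in this assay. They also leave open what an amine in place of the nitro group or the chlorine would give.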